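This account rests on a few compounds, and the source may have more. Where it says the series, first, only, none or still open, it means among the compounds named here.

Compound 3 `O=[N+]([O-])c1ccc(Oc2ncnc3[nH]ccc23)cc1` stands at a limit in an assay on HEK293-TREx cells for antagonist activity at transient receptor potential cation channel subfamily A member 1 (Homo sapiens), read by fluorescence and calcium flux, with a stated time of 72 h; a lower number here means a stronger inhibitor, a higher number a weaker inhibitor: compound 3 gives > 32000 nM, which is a limit of the assay and not a number. Compound 2 `N#Cc1ccc(Oc2ncnc3[nH]ccc23)cc1` likewise sits at a limit, giving > 32000 nM. Only compound 1 `c1ccc(Oc2ncnc3[nH]ccc23)cc1` gives a number, 3200 nM. The change from compound 3 to compound 4 `COc1ccc(Oc2ncnc3[nH]ccc23)cc1` is methoxy in place of nitro on an aromatic carbon. Bearing on it are an at least 10-fold higher number from compound 1 to compound 2 (1.00 log units; beyond the scatter) and an at least 10-fold higher number from compound 1 to compound 3 (1.00 log units; beyond the scatter), both of which ran into (the limit of > 32000 nM in this assay, at which 2 of the 3 values shown sit), while a step that the two limits leave unreadable from compound 2 to compound 3. Among the measured compounds shown here, no measured step involves a methoxy group, so the direction is open. The step is estimated as an at least 5.3-fold lower number from compound 3 to compound 4 (0.72 log units; beyond the scatter), a move down from the limit toward the number of compound 1. Compound 4 is expected at 6000 nM, between 1500 nM and 32000 nM.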

Compound 4, half-maximal inhibitory concentration: > 32000 nM
Compound 4 gave a limit, no number; the forecaster's own chance of this, stated with the estimate: 30%; middle value at least 5.3-fold (0.72 log units) away from the limit.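

Methoxy in place of hydrogen, on an aromatic carbon para to a large group, gives an at least 10-fold higher number from compound 1 to compound 4 (1.00 log units; beyond the scatter) in this assay. Methoxy thus joins cyano and nitro, and among the compounds shown only compound 1, with hydrogen at this place, gives a number. The steps among compound 2, compound 3 and compound 4 cannot be read, since each value is a limit of the assay and not a number: the limit of > 32000 nM in this assay, at which 3 of the 4 values shown sit.

As far as these compounds go, whether fluorine, a methyl group or an amine at this place would keep a measurable number stays open. So does whether any group here could give a lower number than compound 1.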